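Shortening the chain on the shared core

The source may hold more compounds than are shown below. What is called first, only, known or untested is meant among the compounds shown, and "the series" means these compounds.

Two compounds of the series have numbers in an assay on mitochondria from L6 cells (Rattus norvegicus) for activation, with a stated time of 90 min; a lower number here means that less compound is needed, a higher number that more compound is needed for the effect. Compound 1, `Oc1nc2nonc2nc1Nc1ccc(OCC(F)(F)F)c(C(F)(F)F)c1`, carries an aromatic substituent on the nitrogen attached to the shared core and in this assay gives 4000 nM. Compound 2, `CCCCCCCCNc1nc2nonc2nc1O`, carries a saturated chain there instead and in this assay gives 3400 nM. Compound 2 has the lower of the two numbers, but compound 1 lies within the usual scatter of it, so the two are read as alike.

The next compound is compound 3, `Oc1nc2nonc2nc1NCCC(F)(F)F`. It differs from compound 2 in one place: trifluoromethyl in place of hexyl on a saturated chain carbon, two bonds along the chain from a nitrogen on an aromatic ring. The chain on compound 3 is thus much shorter than the octyl chain of compound 2. Within the data shown here, no step between measured compounds shows what a change of this kind does here; the two values known so far only show that an aromatic group and a long saturated chain end up in the same range. The expectation for the step is a moderate rise, a 2.6-fold higher number from compound 2 to compound 3 (0.42 log units; beyond the scatter), since the shorter chain is taken to give back some of what compound 2 shows with 3400 nM. Compound 3 is estimated at 9000 nM, with a range from 3000 nM to 30000 nM.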

Compound 3, half-maximal effective concentration: 110000 nM
Compound 3: middle estimate off by 12-fold (1.09 log units), on the low side; the whole stated range lies below it.
By their numbers in this assay, from the lowest: compounds 2 and 1 (each within the scatter of the next); then compound 3.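

On a saturated chain carbon, two bonds along the chain from a nitrogen on an aromatic ring, this assay is sensitive to the group carried: trifluoromethyl in place of hexyl gives a 32-fold higher number from compound 2 to compound 3 (1.51 log units; beyond the scatter). Among these compounds, the earlier compounds showed only that an aromatic group and a long saturated chain on that nitrogen end up in the same range, which could suggest a tolerant position, whereas this step shows that a change confined to the saturated chain can move the number far beyond the scatter. Nothing among the data shown gives a reason for the size of this step.

The one step shortens the chain and brings in fluorine together, and the compounds shown do not separate these two changes or tell which of them goes with the much higher number. A plain butyl group at this place would address the chain length alone, while a longer chain carrying trifluoromethyl, an amine or a carboxylic acid would show how far other groups on the chain are accepted.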